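Swapping trifluoromethyl for methyl on a related core

This account rests on a few compounds, and the source may have more. Where it says the series, first, only, none or still open, it means among the compounds named here.

Measured compounds:
compound 1, `Cc1ccc2[nH]c(-c3cn(-c4ccccc4)nc3-c3ccccc3)nc2c1`: 3610 nM
compound 2, `FC(F)(F)c1ccc2[nH]c(-c3cn(-c4ccccc4)nc3-c3ccccc3)nc2c1`: 5930 nM
compound 3, `FC(F)(F)c1ccc2[nH]c(-c3cn(-c4ccccc4)nc3-c3ccc(Cl)cc3)nc2c1`: 3360 nM

All three were tested in a functional assay on A549 cells (Homo sapiens) for antiproliferative activity, read by MTT assay, with a stated time of 48 h; a lower number here means a stronger inhibitor, a higher number a weaker inhibitor. Compound 3 and compound 2 share most of their structure; the difference is chloro in place of hydrogen on an aromatic carbon, and the step that goes with it is a 1.8-fold lower number from compound 2 to compound 3 (0.25 log units; within the scatter).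

The change now in view, (methyl in place of trifluoromethyl on an aromatic carbon), has already been made once, giving a 1.6-fold lower number from compound 2 to compound 1 (0.22 log units; within the scatter).

Compound 4, `Cc1ccc2[nH]c(-c3cn(-c4ccccc4)nc3-c3ccc(Cl)cc3)nc2c1`, is not yet measured. It differs from compound 3 by methyl in place of trifluoromethyl on an aromatic carbon, the same change made on a core that carries chloro instead of hydrogen. Because the earlier step was a 1.6-fold lower number from compound 2 to compound 1 (0.22 log units; within the scatter), a step of similar size, a 1.4-fold lower number from compound 3 to compound 4 (0.15 log units; within the scatter), is expected here. Compound 4 is therefore estimated at 2400 nM, likely between 1000 nM and 5500 nM.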

Compound 4, half-maximal inhibitory concentration: 4640 nM
Estimate against measurement, compound 4: 1.9-fold (0.29 log units) below, and the stated range covers the measured number.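

In this assay, methyl in place of trifluoromethyl on the chloro-bearing core gives a 1.4-fold higher number from compound 3 to compound 4 (0.14 log units; within the scatter), and chloro in place of hydrogen on the methyl-bearing core gives a 1.3-fold higher number from compound 1 to compound 4 (0.11 log units; within the scatter). Set beside its earlier counterpart, the methyl change leaves a gap no larger than repeated measurements could produce: the same change on two cores in this assay, a 1.6-fold lower number (0.22 log units; within the scatter) from compound 2 to compound 1 and a 1.4-fold higher number (0.14 log units; within the scatter) from compound 3 to compound 4, 2.3-fold (0.36 log units) apart, within the scatter of two such steps. The chloro change reads the same way, so nothing here shows that either change behaves differently on the two cores, but with steps this small, nothing shows that a real effect carries over either: the same change on two cores in this assay, a 1.8-fold lower number (0.25 log units; within the scatter) from compound 2 to compound 3 and a 1.3-fold higher number (0.11 log units; within the scatter) from compound 1 to compound 4, 2.3-fold (0.36 log units) apart, within the scatter of two such steps.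

As far as these compounds go, it remains open whether a step clearly beyond the scatter would carry from one core to the other. An amine, a carboxylic acid or a longer chain in place of the methyl, on both cores, could test this.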